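The compounds below may be only part of what the source reports. "The series", "measured", "known", "first", "only" and "open" are said of these compounds alone.

Series notes, carbonyl substituent on the shared core.

Compound 3 `O=C(NC[C@@H]1C[C@@H]2C=C[C@@H]1C2)NS(=O)(=O)N1CCC(CCNC(=O)c2cc(Cl)ccn2)CC1` stands highest of the three measured compounds in a functional assay on the whole organism (blood) with Rattus norvegicus as the target, with stated times of 24 h and 1 h, at a dose of 5 mg/kg by the intraperitoneal route (on this read-out lower numbers stand for a weaker effect and higher numbers for a stronger effect at the one dose given), where compound 3 gives 32%. Compound 1 `CC(=O)NCCC1CCN(S(=O)(=O)NC(=O)NC[C@@H]2C[C@@H]3C=C[C@@H]2C3)CC1` gives 18% in this assay, and compound 2 `Cc1cccc(C(=O)NCCC2CCN(S(=O)(=O)NC(=O)NC[C@@H]3C[C@@H]4C=C[C@@H]3C4)CC2)n1` gives 20%. The two values of compound 1 and compound 2 sit within the scatter of each other, as the step of a number 2 percentage points higher from compound 1 to compound 2 (within the scatter) shows. Beyond the scatter are a number 14 percentage points higher from compound 1 to compound 3 (beyond the scatter) and a number 12 percentage points higher from compound 2 to compound 3 (beyond the scatter), both modest.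

Compound 4 `O=C(NC[C@@H]1C[C@@H]2C=C[C@@H]1C2)NS(=O)(=O)N1CCC(CCNC(=O)c2nc3ccccc3s2)CC1` is not yet measured. It differs from compound 3 in one place: 1,3-benzothiazol-2-yl in place of 4-chloropyridin-2-yl on a carbonyl carbon.

Of the measured steps, only a number 12 percentage points higher from compound 2 to compound 3 (beyond the scatter) exchanges one aromatic group for another on the carbonyl carbon, and it was modest; a number 14 percentage points higher from compound 1 to compound 3 (beyond the scatter) and a number 2 percentage points higher from compound 1 to compound 2 (within the scatter) start from methyl and bear less directly. Within the data shown here, no measured step introduces a 1,3-benzothiazol-2-yl group, so its direction is not known from this series. Among the measured compounds shown here, all changes at this position so far have stayed modest, and a step of similar size in either direction, or none beyond the scatter, is the reasonable expectation.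

Compound 4 is therefore estimated at 30% in this assay, within 16% to 46%, which means an expected step of a number 2 percentage points lower from compound 3 to compound 4 (within the scatter).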

Compound 4, a percentage reported as activity, at one dose (the size of the read-out at that dose, not a potency): 24%
Compound 4: the middle estimate sits 6 percentage points above what was measured; the measured number falls inside the stated range.
By their numbers in this assay, from the lowest: compounds 1, 2, 4 and 3 (each within the scatter of the next, the first and the last beyond it).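

Working notes on the result. In this assay, 1,3-benzothiazol-2-yl in place of 4-chloropyridin-2-yl gives a number 8 percentage points lower from compound 3 to compound 4 (within the scatter) and so does not separate the two groups, and the comparisons with the other two compounds, a number 4 percentage points higher from compound 2 to compound 4 (within the scatter) and a number 6 percentage points higher from compound 1 to compound 4 (within the scatter), read the same way. Among these compounds, compound 4 is thus the first compound that cannot be told apart from either compound 1 or compound 3, although those two lie beyond the scatter of each other. This position therefore accepts an aromatic group with a five-membered ring and a six-membered ring, but the data do not show whether that group shares the higher number of compound 3 or the lower number of compound 1; no measurement at hand offers a reason for any of these steps.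

Open, going by these compounds, is whether plain pyridin-2-yl, without the chlorine, or a single five-membered ring such as thiazol-2-yl on the carbonyl carbon would stand apart from compound 1 in this assay. Also open, on these data alone, is how an amine or a carboxylic acid on the aromatic group would read at this position.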